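The compounds below may be only part of what the source reports. "The series", "measured", "known", "first", "only" and "open" are said of these compounds alone.

Compound 3 `Clc1ccc(Oc2ccc3c(NCCCNCc4ccco4)ccnc3c2)cc1` stands level with compound 1 `CC(C)(C)c1ccc(Oc2ccc3c(NCCCNCc4ccco4)ccnc3c2)cc1` at the digits shown in an ADME assay for permeability, using PAMPA, with a stated time of 30 min, at pH 7.4 (a lower number here means that the compound crosses the layer more slowly, a higher number that the compound crosses the layer faster), where compound 3 gives 317 10^-6 cm/s and compound 1 gives 317 10^-6 cm/s; compound 2 `Fc1ccc(-c2ccc3c(NCCCNCc4ccco4)ccnc3c2)cc1` gives 237 10^-6 cm/s, within the scatter of both. Compound 4 `COc1ccc(Oc2ccc3c(NCCCNCc4ccco4)ccnc3c2)cc1` differs from compound 3 by methoxy in place of chloro on an aromatic carbon. Going by the values given here, two measured steps bear on this change: no change at the digits printed from compound 1 to compound 3 (within the scatter) and a 1.3-fold higher number from compound 2 to compound 3 (0.13 log units; within the scatter), both within the scatter, so swapping the group on this outer ring, or the link to it, has so far left this assay essentially unmoved. A methoxy in place of chloro is therefore expected to give no step beyond the scatter, estimated as a 1.1-fold lower number from compound 3 to compound 4 (0.04 log units; within the scatter). For compound 4 the estimate is 290 10^-6 cm/s, with a range from 180 10^-6 cm/s to 430 10^-6 cm/s.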

Compound 4, apparent permeability: 317 10^-6 cm/s
The estimate for compound 4 lay 1.1-fold (0.04 log units) below the measured number; low and high end bracket the measured number.
By their numbers in this assay, from the lowest: compounds 2, 1, 3 and 4 (each within the scatter of the next).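

Swapping chloro for methoxy adds a hydrogen-bond acceptor at this place on the outer ring, yet this assay shows no change at the digits printed from compound 3 to compound 4 (within the scatter). The comparisons with the other two compounds agree, with no change at the digits printed from compound 1 to compound 4 (within the scatter) and a 1.3-fold higher number from compound 2 to compound 4 (0.13 log units; within the scatter), so three different groups at this position now give matching results. No measurement shown here explains this flat result.

Still open, on these data alone, is whether an amine or a carboxylic acid at this place would shift the number in this assay, and whether changes elsewhere in the shared core would do so.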